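Moving the Methoxy Group on the Pendant Phenyl

This account rests on a few compounds, and the source may have more. Where it says the series, first, only, none or still open, it means among the compounds named here.

Measured so far in an assay for binding affinity to Alpha-1B adrenergic receptor (Homo sapiens); a higher number here means a weaker inhibitor, a lower number a stronger inhibitor:
compound 1 `CN1CCC[C@@H]1Cn1nc(Cc2ccc(O)cc2)c2ccccc2c1=O` gives 398 nM
compound 2 `COc1ccc(Cc2nn(C[C@H]3CCCN3C)c(=O)c3ccccc23)cc1OC` gives > 1990 nM
compound 3 `COc1cccc(Cc2nn(C[C@H]3CCCN3C)c(=O)c3ccccc23)c1` gives > 1990 nM

The value for compound 3 is a limit of this assay, not a number. The value for compound 2 is likewise a limit, so two of the three values sit at the limit of > 1990 nM in this assay, at which 2 of the 3 values shown sit, and only compound 1 carries a number. Compound 3 therefore stands at the weak end of what has been measured: an at least 5.0-fold higher number from compound 1 to compound 3 (0.69 log units; beyond the scatter). The step that the two limits leave unreadable from compound 2 to compound 3 cannot be sized, since both ends are limits.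

Compound 4 `COc1ccc(Cc2nn(C[C@H]3CCCN3C)c(=O)c3ccccc23)cc1` is not yet measured. It differs from compound 3 by 4-methoxyphenyl in place of 3-methoxyphenyl on a saturated chain carbon bound to an aromatic carbon. Of the measured steps, only an at least 5.0-fold higher number from compound 1 to compound 3 (0.69 log units; beyond the scatter) bears on this position, and it compares a hydroxy with a methoxy on different carbons, so it does not fix the direction. Compound 2, with methoxy on both carbons, is a limit, so adding a fourth-position methoxy did not pull the value into the numbered range. The expected step of an at least 1.1-fold lower number from compound 3 to compound 4 (0.04 log units; that floor lies within the scatter) is therefore small or none beyond the scatter. For compound 4 the estimate is 1800 nM, within 500 nM to 6000 nM.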

Compound 4, inhibition constant: 158 nM
The estimate for compound 4 lay 11-fold (1.06 log units) above the measured number; measured number outside the range, below it.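

In this assay, where the methoxy sits on the phenyl decides the result: 4-methoxyphenyl in place of 3-methoxyphenyl gives an at least 12-fold lower number from compound 3 to compound 4 (1.10 log units; beyond the scatter), so a methoxy is tolerated on this ring when it is placed as in 4-methoxyphenyl. The further methoxy of compound 2 is not tolerated, since hydrogen in its place gives an at least 12-fold lower number from compound 2 to compound 4 (1.10 log units; beyond the scatter), while methyl in place of hydrogen on the oxygen gives a 2.5-fold lower number from compound 1 to compound 4 (0.40 log units; beyond the scatter), so the free hydroxy is not needed for the stronger values. Compound 2 and compound 3 each carry a limit of the assay, not a number, so the first two steps are floors: the limit of > 1990 nM in this assay, at which 2 of the 4 values shown sit.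

The step between compound 2 and compound 3 cannot be read. On these data alone, whether 4-ethoxyphenyl or 4-chlorophenyl would match 4-methoxyphenyl at this place remains open.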